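Removing the hydroxyl from a uracil bearing two benzyl ethers

A few compounds are considered here, and "the series" means these few. Any claim that something is new, unique, unknown or untested is made for them only; others in the source may bear on it.

Compound 1 `COCn1c(CC(O)(COCc2ccccc2)COCc2ccccc2)cc(=O)[nH]c1=O` carries a hydroxy on the carbon that links its side chain. In a functional assay on SW-620 cells (Homo sapiens) for antiproliferative activity, read by MTT assay, with a stated time of 72 h (a lower number here means a stronger inhibitor, a higher number a weaker inhibitor), compound 1 gives only a limit, > 100000 nM. Compound 2 `C[Si](C)(C)CCOCn1c(CC(O)(COCc2ccccc2)COCc2ccccc2)cc(=O)[nH]c1=O` likewise gives only a limit in this assay, > 100000 nM. Compound 3 `C[Si](C)(C)CCOCn1c(CC(O)(CO)CO)cc(=O)[nH]c1=O` also gives only a limit in this assay, > 100000 nM. Within the data shown here, the one step that joins two of these, a step that the two limits leave unreadable from compound 1 to compound 2, is therefore unreadable, because the limit of > 100000 nM in this assay, at which 3 of the 3 values shown sit, holds every value shown. Compound 4 `COCn1c(CC(COCc2ccccc2)COCc2ccccc2)cc(=O)[nH]c1=O` differs from compound 1 by hydrogen in place of hydroxy on a saturated chain carbon bound to three saturated chain carbons. Among the measured compounds shown here, no measured step bears directly on this change. Compound 4 is expected to sit again at the limit, estimated at 150000 nM (range 50000 nM to 500000 nM). The expected step is therefore a step that the limit leaves unreadable from compound 1 to compound 4, none beyond the scatter.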

Compound 4, half-maximal inhibitory concentration: > 100000 nM
Compound 4 ended at the assay's limit; the forecaster's own chance of this, stated with the estimate: 85%; the middle value does not contradict the limit.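

The step from compound 1 to compound 4 cannot be read, because both values are limits: the limit of > 100000 nM in this assay, at which 4 of the 4 values shown sit.

The compounds shown leave open whether swapping hydroxy for hydrogen changes anything in this assay, since none gives a measurable value there.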